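The source may hold more compounds than are shown below. What is called first, only, known or untested is meant among the compounds shown, and "the series" means these compounds.

Measured compounds:
Compound 1, `COc1cc2c(Oc3ccc(NC(=O)c4nn(-c5ccccc5)c(=O)cc4C)cc3F)ccnc2cc1OCCCN1CCCC1`, gives 120 nM in a functional assay on MKN-45 cells (Homo sapiens) for inhibition, read by MTT assay, with a stated time of 72 h; a lower number here means a stronger inhibitor, a higher number a weaker inhibitor.
Compound 2, `COc1cc2c(Oc3ccc(NC(=O)c4nn(-c5ccccc5OC(F)(F)F)c(=O)cc4C)cc3F)ccnc2cc1OCCCN1CCCC1`, gives 60 nM in this assay.

Within the data shown here, compound 2 stands at the lower end of the two numbers recorded, but its only neighbour is compound 1, and the step of a 2.0-fold lower number from compound 1 to compound 2 (0.30 log units; within the scatter) lies within the scatter, so the two cannot be told apart. Compound 3, `COc1cc2c(Oc3ccc(NC(=O)c4nn(-c5cccc(F)c5)c(=O)cc4C)cc3F)ccnc2cc1OCCCN1CCCC1`, has not yet been measured. It differs from compound 2 in one place: 3-fluorophenyl in place of 2-(trifluoromethoxy)phenyl on an aromatic nitrogen. Among the measured compounds shown here, only one measured step bears on a change at this aromatic nitrogen: a 2.0-fold lower number from compound 1 to compound 2 (0.30 log units; within the scatter), an amount that does not rise above the scatter. For the measured compounds named here, that step concerned trifluoromethoxy against hydrogen; the change to compound 3 replaces the whole 2-(trifluoromethoxy)phenyl with 3-fluorophenyl, and no measured pair covers a fluorine on that ring. Going by the values given here, with one step of that size as the only guide, no shift beyond the scatter is expected for compound 3 in this assay, that is, about a 1.4-fold higher number from compound 2 to compound 3 (0.15 log units; within the scatter). Compound 3 is therefore estimated at 85 nM, with a likely range from 30 nM to 250 nM.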

Compound 3, half-maximal inhibitory concentration: 120 nM
For compound 3 the middle estimate is 1.4-fold (0.15 log units) below the measured one, within the range that was stated.
By their numbers in this assay, from the lowest: compounds 2, 1 and 3 (each within the scatter of the next).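

In this assay, the group on the aromatic nitrogen now appears in three forms, and both new comparisons stay within the scatter: exchanging the whole 2-(trifluoromethoxy)phenyl for 3-fluorophenyl gives a 2.0-fold higher number from compound 2 to compound 3 (0.30 log units; within the scatter), while fluoro in place of hydrogen on the ring gives no change at the digits printed from compound 1 to compound 3 (within the scatter). Among these compounds, the second comparison is the first measured one for a fluorine on this ring, and it shows no difference from the unsubstituted phenyl of compound 1 at the digits printed. Across these three compounds, then, neither fluoro nor trifluoromethoxy on this ring yields a step that rises above the scatter, and nothing available offers an explanation for this result.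

Going by these compounds, it remains open whether any change at this aromatic nitrogen can move the number beyond the scatter, for instance an amine or a carboxylic acid on the ring, or a longer alkyl chain in place of the ring. The compounds shown also leave open whether fluoro and trifluoromethoxy would behave alike if each were placed elsewhere on the ring.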